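The source may report more compounds than this note shows. Statements on the series, on what has been measured and on what is new or still open speak of the compounds shown alone.

Measured in a functional assay on HT-29 cells (Homo sapiens) for cytotoxicity, read by XTT assay, with a stated time of 72 h; on this read-out lower numbers stand for stronger inhibition and higher numbers for weaker inhibition:
- compound 1 `CCn1ccc2cc(/C(=N\O)c3cc(OC)c(OC)c(OC)c3)ccc21`: > 1000 nM
- compound 2 `CCn1ccc2cc(/C(=N\OC(C)=O)c3cc(OC)c(OC)c(OC)c3)ccc21`: > 1000 nM
- compound 3 `CCn1ccc2cc(/C(=N/OC(C)=O)c3cc(OC)c(OC)c(OC)c3)ccc21`: > 10000 nM

Each of these three values is a limit of the assay and not a number. Compound 2 stands only at its limit of > 1000 nM, and this gives it no exact place in the series. The evidence consists of the limit of > 1000 nM in this assay, at which 2 of the 3 values shown sit, and of the limit of > 10000 nM in this assay, at which 1 of the 3 values shown sits, with no number in between.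

Compound 4 `CCn1ccc2cc(/C(=N\N)c3cc(OC)c(OC)c(OC)c3)ccc21` is reached from compound 2 by the change (amino in place of acetoxy on a double-bonded nitrogen). Among the compounds with values here, two measured steps touch this part of the structure. Within the data shown here, the first is a step that the two limits leave unreadable from compound 1 to compound 2, with acetyl in place of hydrogen on an oxygen. The second is a step that the two limits leave unreadable from compound 2 to compound 3, and it concerns (the fact that compounds 2 and 3 differ only in the configuration as drawn). Neither step has a readable size, and neither involves an amino group, so they set no size for the new change in this assay and no direction.

The expected outcome is therefore wide, and the estimated step is a step that the limit leaves unreadable from compound 2 to compound 4 in no firmly expected direction. Compound 4 is expected at about 1500 nM, with an estimated range from 200 nM to 10000 nM and a real chance of another limit.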

Compound 4, half-maximal inhibitory concentration: > 1000 nM
Compound 4 ended at the assay's limit; the forecaster's own chance of this, stated with the estimate: 55%; the middle value does not contradict the limit.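

In this assay compound 4 gives > 1000 nM, which is a limit of the assay and not a number. No step leading to compound 4 from compound 1 or compound 2 can be read, since all three stand at the same limit: the limit of > 1000 nM in this assay, at which 3 of the 4 values shown sit.

The compounds shown leave open how amino, hydroxy and acetoxy on the double-bonded nitrogen compare in this assay.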